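Replacing a piperidine with a halogenated aniline on the shared core

This account rests on a few compounds, and the source may have more. Where it says the series, first, only, none or still open, it means among the compounds named here.

Compound 1 `FC(F)(F)c1ccc(CSc2nc(N3CCCCC3)c3ccccc3n2)cc1` gives 28400 nM in a functional assay on MDA-MB-231 cells (Homo sapiens) for cytotoxicity, read by MTT assay, with a stated time of 72 h (on this read-out higher numbers stand for weaker inhibition and lower numbers for stronger inhibition), the highest number among the three measured compounds. Compound 2 `FC(F)(F)c1ccc(CSc2nc(Nc3ccc(C(F)(F)F)cc3)c3ccccc3n2)cc1` gives 5460 nM and compound 3 `COc1cc(Nc2nc(SCc3ccc(C(F)(F)F)cc3)nc3ccccc23)cc(OC)c1` gives 16100 nM in this assay. The change to compound 4 `Fc1ccc(Nc2nc(SCc3ccc(C(F)(F)F)cc3)nc3ccccc23)cc1Cl` is (3-chloro-4-fluorophenyl)amino in place of piperidin-1-yl on an aromatic carbon. Among the measured compounds shown here, two measured steps bear on it: a 5.2-fold lower number from compound 1 to compound 2 (0.72 log units; beyond the scatter) and a 1.8-fold lower number from compound 1 to compound 3 (0.25 log units; within the scatter). The aryl group entering in compound 4 carries halogens, like that of compound 2, so a modest lowering is expected rather than none. Compound 4 is therefore expected to give about 7500 nM, within 3000 nM to 18000 nM. That estimate corresponds to a 3.8-fold lower number from compound 1 to compound 4 (0.58 log units; beyond the scatter).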

Compound 4, half-maximal inhibitory concentration: 14500 nM
The estimate for compound 4 lay 1.9-fold (0.29 log units) below the measured number; the range from low to high includes it.
By their numbers in this assay, from the lowest: compound 2; then compounds 4, 3 and 1 (each within the scatter of the next).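

Halogens on the aryl group do not by themselves bring the lowering seen with compound 2. The new group gives a 2.0-fold lower number from compound 1 to compound 4 (0.29 log units; within the scatter), and exchanging the aryl group gives a 1.1-fold lower number from compound 3 to compound 4 (0.05 log units; within the scatter), so 3-chloro-4-fluorophenyl and 3,5-dimethoxyphenyl cannot be told apart here, while 4-(trifluoromethyl)phenyl differs, with a 2.7-fold higher number from compound 2 to compound 4 (0.42 log units; beyond the scatter). No measurement at hand explains this difference. From the compounds shown here alone, it remains open whether the lower number of compound 2 belongs to the trifluoromethyl group itself. An aryl group carrying a nitrile or a carboxylic acid in its place could test that.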